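A few compounds are considered here, and "the series" means these few. Any claim that something is new, unique, unknown or untested is made for them only; others in the source may bear on it.

Measured so far in a functional assay on P388 cells (Mus musculus) for inhibition, tested at 100 uM; a lower number here means a weaker effect, a higher number a stronger effect of the compound at the concentration tested:
Compound 1 `Cc1ccc(S(=O)(=O)n2cc(-c3cc(C(F)(F)F)ccn3)c3cc(OCc4ccccc4)ccc32)cc1` gives 2.2%.
Compound 2 `COc1ccc2c(c1)c(-c1cc(C(F)(F)F)ccn1)cn2S(=O)(=O)c1ccc(C)cc1` gives 15.6%.
Compound 3 `COc1ccc2c(-c3cc(C(F)(F)F)c(C#N)c(-c4cn(S(=O)(=O)c5ccc(C)cc5)c5cc(OC)ccc45)n3)cn(S(=O)(=O)c3ccc(C)cc3)c2c1` gives 3.8%.

Compound 3 stands second highest of these three numbers; compound 1 lies nearest, a little lower but within the usual scatter, while compound 2 lies furthest, higher by a margin beyond the scatter. The untested compound 4 `COc1ccc2c(-c3cc(C(F)(F)F)cc(-c4cn(S(=O)(=O)c5ccc(C)cc5)c5cc(OC)ccc45)n3)cn(S(=O)(=O)c3ccc(C)cc3)c2c1` differs from compound 3 in one place: hydrogen in place of cyano on an aromatic carbon.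

Among the compounds with values here, the only step measured so far, a number 13.4 percentage points higher from compound 1 to compound 2 (beyond the scatter), concerns a different group at a different place on the shared core, so it gives no guidance on removing the cyano group. With nothing that bears on this change, compound 4 is expected to show a number 1.2 percentage points higher from compound 3 to compound 4 (within the scatter). Compound 4 is therefore estimated at 5%, within a range from -6% to 18%.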

Compound 4, a percentage reported as inhibition, at one concentration (the size of the read-out at that concentration, not a potency): 99.9%
Beside the measured number, compound 4's estimate is 94.9 percentage points below it; measured number outside the range, above it.
By their numbers in this assay, from the lowest: compounds 1 and 3 (each within the scatter of the next); then compound 2; then compound 4.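

Putting hydrogen in place of cyano on this aromatic carbon, ortho to a trifluoromethyl group, gives a number 96.1 percentage points higher from compound 3 to compound 4 (beyond the scatter) in this assay. The earlier compounds shown here held no change at this place, and this step shows that a single small group here can shift the read-out across most of its scale. No available data explain this large step. Open, from the compounds shown here alone, is whether an amine, a carboxylic acid or a methyl group at this carbon would give a number like that of compound 4 or that of compound 3. Also open, going by these compounds, is whether the same swap acts alike with other groups on the shared core.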